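Acetyl in Place of Methoxy on the Fluorophenoxy Arm

The compounds below may be only part of what the source reports. "The series", "measured", "known", "first", "only" and "open" are said of these compounds alone.

Compound 1 `CN(C)c1ccc(C(=O)Nc2cccc(NC(=O)COc3ccc4c(c3)NC(=O)CC4)c2)cc1`: 3140 nM
Compound 2 `COc1cc(OCC(=O)Nc2cccc(NC(=O)c3ccc(N(C)C)cc3)c2)ccc1C=O`: 306 nM
Compound 3 `COc1ccc(OCC(=O)Nc2cccc(NC(=O)c3ccc(N(C)C)cc3)c2)cc1F`: 652 nM
Compound 4 `CC(=O)c1ccc(OCC(=O)Nc2cccc(NC(=O)c3ccc(N(C)C)cc3)c2)cc1F`: not yet measured

In an assay on isolated protein for inhibition of Rho-associated protein kinase 2 (Homo sapiens), read by scintillation counting, radiometric assay and 33P incorporation, with a stated time of 40 min, in the presence of a further agent that is not named here (on this read-out higher numbers stand for weaker inhibition and lower numbers for stronger inhibition), compound 3 holds the second highest of the three numbers: a 2.1-fold higher number from compound 2 to compound 3 (0.33 log units; beyond the scatter), while a 4.8-fold lower number from compound 1 to compound 3 (0.68 log units; beyond the scatter). Compound 4 carries acetyl in place of methoxy on an aromatic carbon. Among the measured compounds shown here, no measured step exchanges this group alone, so the bearing is indirect. Compound 2, whose aryl ring also carries a carbonyl, gave the lowest number of the three, and the step of a 2.1-fold higher number from compound 2 to compound 3 (0.33 log units; beyond the scatter) was modest, suggesting a carbonyl on this ring is at least tolerated. A modest lowering or no step beyond the scatter is therefore expected. Compound 4 is estimated at 450 nM, within 150 nM to 1400 nM. That estimate amounts to a 1.4-fold lower number from compound 3 to compound 4 (0.16 log units; within the scatter).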

Compound 4, half-maximal inhibitory concentration: 98 nM
The estimate for compound 4 lay 4.6-fold (0.66 log units) above the measured number; measured number outside the range, below it.
By their numbers in this assay, from the lowest: compound 4; then compound 2; then compound 3; then compound 1.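

In this assay, acetyl in place of methoxy on this aromatic carbon, ortho to a fluoro group, gave a 6.7-fold lower number from compound 3 to compound 4 (0.82 log units; beyond the scatter), showing that this position responds strongly to the exchange and does more than tolerate a carbonyl. The new aryl group also surpassed the other two, with a 3.1-fold lower number from compound 2 to compound 4 (0.49 log units; beyond the scatter) and a 32-fold lower number from compound 1 to compound 4 (1.51 log units; beyond the scatter). No evidence is available to explain these steps.

The compounds shown leave open whether a carboxylic acid, a primary amide or a longer propanoyl chain would serve here as well as acetyl. They also leave open what acetyl does with hydrogen in place of the fluoro group.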